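The compounds below may be only part of what the source reports. "The series", "measured", "known", "first", "only" and "open" are said of these compounds alone.

Measured so far:
Compound 1, `CCCC[C@@H](CO)Nc1nc(N)nc2cccnc12`: 420 nM
Compound 2, `CCCC[C@H](CO)Nc1nc(N)nc2cccnc12`: 790 nM

In an assay on tissue (PBMC cells) for agonist activity at Toll-like receptor 8 (Homo sapiens), with a stated time of 24 h (a higher number here means that more compound is needed for the effect, a lower number that less compound is needed), compound 1 gives 420 nM. Compound 2 gives 790 nM in this assay. The two stand apart only by a 1.9-fold higher number from compound 1 to compound 2 (0.27 log units; within the scatter), a gap that rests on (the fact that compounds 1 and 2 differ only in the configuration as drawn), so compound 2 and compound 1 are not separated beyond the scatter on these two numbers.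

Compound 3, `CCCC[C@@H](Nc1nc(N)nc2cccnc12)C(N)=O`, has not been measured. It differs from compound 2 in that (carbamoyl in place of hydroxymethyl on a saturated chain carbon bound to a nitrogen on an aromatic ring and a saturated chain carbon). Within the data shown here, the only measured step, the one from compound 1 to compound 2, concerns a change of configuration alone and says nothing about exchanging a hydroxymethyl for a carbamoyl; no measured pair speaks to that exchange. Among the measured compounds shown here, with no bearing step to draw on, the step from compound 2 to compound 3 is expected to be a 1.0-fold higher number from compound 2 to compound 3 (0.01 log units; within the scatter), with wide uncertainty in either direction. Compound 3 is therefore estimated at 800 nM in this assay, within a range from 200 nM to 3200 nM.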

Compound 3, half-maximal effective concentration: 36000 nM
For compound 3 the middle estimate is 45-fold (1.65 log units) below the measured one, and the stated range ends below it.
By their numbers in this assay, from the lowest: compounds 1 and 2 (each within the scatter of the next); then compound 3.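

The hydroxymethyl group at this position, on a saturated chain carbon bound to a nitrogen on an aromatic ring and a saturated chain carbon, cannot be exchanged freely: in this assay the carbamoyl exchange gives a 46-fold higher number from compound 2 to compound 3 (1.66 log units; beyond the scatter), while the earlier change of configuration alone gave only a 1.9-fold higher number from compound 1 to compound 2 (0.27 log units; within the scatter). The two groups have the same printed counts of hydrogen-bond donors and acceptors and no net charge, so those counts do not follow this step. Nothing at hand gives a cause for the step.

The compounds shown leave open whether a carboxylic acid, a methyl ester or an aminomethyl group at this place would fare as poorly as carbamoyl. They also leave open whether the opposite configuration of the carbamoyl compound would give a different number.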